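Carboxy to methoxymethyl on the chain at the aromatic nitrogen

The compounds below may be only part of what the source reports. "The series", "measured", "known", "first", "only" and "open" are said of these compounds alone.

Measured compounds:
compound 1, `CCCn1c(=O)n(CC(=O)O)c(=O)c2[nH]cnc21`: > 200000 nM
compound 2, `CCCn1c(=O)n(CCC#N)c(=O)c2[nH]cnc21`: 15900 nM

In an assay on Cerebral cortex for binding affinity to adenosine receptor A1 (Cavia porcellus), read by radioligand binding (on this read-out higher numbers stand for weaker inhibition and lower numbers for stronger inhibition), compound 1 gives only a limit, > 200000 nM; this is the limit (the limit of > 200000 nM in this assay, at which 1 of the 2 values shown sits). Compound 2 gives 15900 nM. The step of an at least 12-fold lower number from compound 1 to compound 2 (1.09 log units; beyond the scatter) is the only measured one that bears on the change considered here. Compound 3, `CCCn1c(=O)n(CCOC)c(=O)c2[nH]cnc21`, differs from compound 1 by methoxymethyl in place of carboxy on a saturated chain carbon bound to an aromatic nitrogen. As in compound 2, the carboxy leaves and a group with one hydrogen-bond acceptor and no net charge enters, so a step of the same direction and of similar size is expected, an at least 10-fold lower number from compound 1 to compound 3 (1.00 log units; beyond the scatter). For compound 3 the estimate is 20000 nM, expected between 5000 nM and 80000 nM.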

Compound 3, inhibition constant: 2500 nM
Beside the measured number, compound 3's estimate is 8.0-fold (0.90 log units) above it; the measured number lies below the stated range.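

In this assay, methoxymethyl in place of carboxy gives an at least 80-fold lower number from compound 1 to compound 3 (1.90 log units; beyond the scatter), and this step starts from a limit rather than a number: the limit of > 200000 nM in this assay, at which 1 of the 3 values shown sits. Losing the carboxy is not the whole of the change, since methoxy in place of cyano still gives a 6.4-fold lower number from compound 2 to compound 3 (0.80 log units; beyond the scatter). The group at the chain end therefore matters even among compounds without the carboxy. On these data alone, whether the methoxy oxygen itself is needed stays open, and a plain butyl chain would test this. A hydroxyl or an amine at the chain end is also untested in these compounds.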